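The compounds below may be only part of what the source reports. "The series", "measured", "known", "first", "only" and "open" are said of these compounds alone.

Measured in a functional assay (trachea) with Cavia porcellus as the target; a higher number here means a weaker inhibitor, a lower number a stronger inhibitor:
- Compound 1 `O=c1c2ccccc2c(-c2cccnc2)nn1CCSc1ccccc1`: 9120 nM
- Compound 2 `CCn1nc(-n2cncn2)c2ccccc2c1=O`: 15800 nM

Compound 2, at 15800 nM, lies within the usual scatter of compound 1, at 9120 nM, so these numbers do not separate the two. Compound 3 `CCn1nc(-c2cncnc2)c2ccccc2c1=O` differs from compound 2 in one place, with pyrimidin-5-yl in place of 1H-1,2,4-triazol-1-yl on an aromatic carbon. Among the measured compounds shown here, no measured pair shows what this exchange does in this assay, so no step beyond the scatter is expected, and that expectation is loose. The estimated step is a 1.3-fold lower number from compound 2 to compound 3 (0.12 log units; within the scatter). Compound 3 is expected at 12000 nM, within an estimated range of 4000 nM to 35000 nM.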

Compound 3, half-maximal inhibitory concentration: 9550 nM
For compound 3 the middle estimate is 1.3-fold (0.10 log units) above the measured one; the range from low to high includes it.
By their numbers in this assay, from the lowest: compounds 1, 3 and 2 (each within the scatter of the next).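

In this assay, placing pyrimidin-5-yl on this aromatic carbon instead of 1H-1,2,4-triazol-1-yl gives a 1.7-fold lower number from compound 2 to compound 3 (0.22 log units; within the scatter), so the two groups are not separated. At this position, then, a six-membered aromatic ring with 2 hetero atoms and a five-membered one with 3 read the same within the scatter. No measurement at hand offers an explanation for this result.

Still open, as far as these compounds go, is whether a plain phenyl ring, an open-chain amine or a carboxylic acid at this position would move the number beyond the scatter.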